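Substituting the Sulfonamide Nitrogen in a Kinase Inhibitor Series

The source may report more compounds than this note shows. Statements on the series, on what has been measured and on what is new or still open speak of the compounds shown alone.

Measured compounds:
Compound 1, `Cn1ccc2ccc(-c3cc(Nc4ccccc4S(N)(=O)=O)cc4nccnc34)cc21`: 265 nM
Compound 2, `Cn1ccc2ccc(-c3cc(Nc4ccccc4S(=O)(=O)N4CCOCC4)cc4nccnc34)cc21`: 36 nM

Compound 1 carries a primary sulfonamide on the aniline ring and is the weaker of the two measured compounds in an assay for inhibition of 6-phosphofructo-2-kinase/fructose-2,6-bisphosphatase 3 (Homo sapiens), read by ADP-Glo, with a stated time of 2 h (a lower number here means a stronger inhibitor, a higher number a weaker inhibitor), where compound 1 gives 265 nM. Within the data shown here, the only measured step leads to compound 2, which in this assay gives 36 nM: a 7.4-fold lower number from compound 1 to compound 2 (0.87 log units; beyond the scatter). Compound 3, `Cn1ccc2ccc(-c3cc(Nc4ccccc4S(=O)(=O)NCC4CCOCC4)cc4nccnc34)cc21`, is not yet measured. It differs from compound 1 by (oxan-4-yl)methyl in place of hydrogen on a sulfonamide nitrogen. Among the measured compounds shown here, that step bears on the single step already seen, since both fill the sulfonamide nitrogen with a ring-bearing group of comparable size, though compound 3 keeps one hydrogen on that nitrogen whereas compound 2 has none. A step in the same direction, of somewhat smaller or similar size, is therefore expected in this assay. For compound 3 an estimate of 70 nM is given, with a range from 25 nM to 200 nM, meaning an expected 3.8-fold lower number from compound 1 to compound 3 (0.58 log units; beyond the scatter).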

Compound 3, half-maximal inhibitory concentration: 26 nM
For compound 3 the middle estimate is 2.7-fold (0.43 log units) above the measured one; low and high end bracket the measured number.
By their numbers in this assay, from the lowest: compounds 3 and 2 (each within the scatter of the next); then compound 1.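

In this assay, a second, different group on the sulfonamide nitrogen also lowers the number: (oxan-4-yl)methyl in place of hydrogen gives a 10-fold lower number from compound 1 to compound 3 (1.01 log units; beyond the scatter), so among these compounds the gain does not require that the nitrogen lose both hydrogens. Changing morpholin-4-yl to ((oxan-4-yl)methyl)amino on the sulfonyl sulfur gives a 1.4-fold lower number from compound 2 to compound 3 (0.14 log units; within the scatter), so the two forms of substitution cannot be told apart here. Nothing available explains either step.

The compounds shown leave open whether the ring oxygen matters, which cyclohexylmethyl or piperidin-1-yl on the same position would test. They also leave open whether a ring is needed at all, or whether a simple methyl or a longer open alkyl chain on that nitrogen would do the same.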